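Swapping the Aryl Group on the Ring Nitrogen

The source may report more compounds than this note shows. Statements on the series, on what has been measured and on what is new or still open speak of the compounds shown alone.

Three compounds share one core and differ only in the group on an amine nitrogen in a ring. In an assay on CHO cells for displacement of a labelled ligand from adenosine receptor A3 (Homo sapiens), read by scintillation counting, with a stated time of 45 min, tested at 1 uM, in the presence of a further agent that is not named here (a lower number here means less inhibition, a higher number more inhibition at the concentration tested (going by the name of the read-out)), compound 1 `CCCn1c(=O)[nH]c2nc(-c3ccc(S(=O)(=O)N4CCN(c5ccc(Cl)cc5F)CC4)cc3)[nH]c2c1=O` gives 14%, compound 2 `CCCn1c(=O)[nH]c2nc(-c3ccc(S(=O)(=O)N4CCN(Cc5cccc(C)c5)CC4)cc3)[nH]c2c1=O` gives 17%, and compound 3 `CCCn1c(=O)[nH]c2nc(-c3ccc(S(=O)(=O)N4CCN(c5cccc(Br)c5)CC4)cc3)[nH]c2c1=O` gives 27%. Compound 3 holds the highest of the three numbers: a number 13 percentage points higher from compound 1 to compound 3 (beyond the scatter), beyond the scatter, and a number 10 percentage points higher from compound 2 to compound 3 (within the scatter), within the scatter. Compound 4 `CCCn1c(=O)[nH]c2nc(-c3ccc(S(=O)(=O)N4CCN(C(C)c5ccccc5)CC4)cc3)[nH]c2c1=O` awaits measurement. Its change from compound 3 is 1-phenylethyl in place of 3-bromophenyl on an amine nitrogen in a ring. Within the data shown here, only the step from 3-methylbenzyl to 3-bromophenyl bears on it, and read in reverse it suggests a small move downward; the estimated step is a number 9 percentage points lower from compound 3 to compound 4 (within the scatter). Compound 4 is therefore expected to give 18%, with a range from 5% to 32%.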

Compound 4, a percentage reported as inhibition, at one concentration (the size of the read-out at that concentration, not a potency): 0%
Estimate against measurement, compound 4: 18 percentage points above; measured number outside the range, below it.
By their numbers in this assay, from the lowest: compound 4; then compounds 1, 2 and 3 (each within the scatter of the next, the first and the last beyond it).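

In this assay the 1-phenylethyl group stands apart from all three earlier groups, with a number 27 percentage points lower from compound 3 to compound 4 (beyond the scatter) and a number 17 percentage points lower from compound 2 to compound 4 (beyond the scatter) and a number 14 percentage points lower from compound 1 to compound 4 (beyond the scatter) as its steps. Among these compounds, compound 4 thus holds the lowest number of the four, showing that a change at this ring nitrogen can separate compounds more widely than the earlier steps did. Nothing available bears on why this step is so large. The compounds shown leave open how a plain benzyl group, a 2-phenylethyl chain or a pyridyl ring would read at this position. They also leave open whether this ranking would hold at other concentrations.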